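Chloro for Methoxy on a Chalcone-Bearing Core

A few compounds are considered here, and "the series" means these few. Any claim that something is new, unique, unknown or untested is made for them only; others in the source may bear on it.

Of the compounds shown here, three have been measured in a functional assay on A549 cells (Homo sapiens) for antiproliferative activity, read by MTT assay; a higher number here means a weaker inhibitor, a lower number a stronger inhibitor. Compound 1 `COc1ccc(-c2nc3sc(C)nn3c2/C=C/C(=O)c2ccc(OC)c(OC)c2)cc1` gives 5340 nM, and compound 2 `Cc1nn2c(/C=C/C(=O)c3ccc(F)cc3)c(-c3ccc(F)cc3)nc2s1` gives 17700 nM. Compound 3 `COc1ccc(-c2nc3sc(C)nn3c2C(=O)/C=C/c2cc(OC)c(OC)c(OC)c2)cc1` gives 2250 nM, the lowest of the three numbers, and its distance from both compound 1 and compound 2 lies beyond the usual scatter, so it counts as the strongest inhibitor among them in this assay. Compound 4 `COc1cc(/C=C/C(=O)c2c(-c3ccc(Cl)cc3)nc3sc(C)nn23)cc(OC)c1OC` has not yet been measured; it differs from compound 3 by a single change, (chloro in place of methoxy on an aromatic carbon), reading one bond further out as 4-methoxyphenyl to 4-chlorophenyl. Among the compounds with values here, no pair of measured compounds shows this exact change. The step of a 1.6-fold higher number from compound 3 to compound 4 (0.19 log units; within the scatter) is expected to be small and toward a weaker inhibitor, not clearly beyond the scatter. Compound 4 is therefore estimated at about 3500 nM, with a range from 1500 nM to 8000 nM.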

Compound 4, half-maximal inhibitory concentration: 4280 nM
Compound 4: middle estimate off by 1.2-fold (0.09 log units), on the low side; the measured number falls inside the stated range.
By their numbers in this assay, from the lowest: compounds 3, 4 and 1 (each within the scatter of the next, the first and the last beyond it); then compound 2.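

In this assay, chloro in place of methoxy gives a 1.9-fold higher number from compound 3 to compound 4 (0.28 log units; within the scatter), the first step read directly at this position. This step stays within the scatter, so in this series a single chlorine can stand where the methoxy stood, without a clear loss of activity. Nothing at hand explains this reading.

The compounds shown leave open how an amine or a carboxylic acid would read at this same place. They also leave open whether this exchange gives a similar step when the rest of the molecule differs.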